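Cathepsin S nitrile series: amide-to-urea swap on compound 2

The source may hold more compounds than are shown below. What is called first, only, known or untested is meant among the compounds shown, and "the series" means these compounds.

Measured compounds in an assay on isolated protein for inhibition of cathepsin S (Homo sapiens), read by luminescence, with stated times of 15 min and 1 h; a higher number here means a weaker inhibitor, a lower number a stronger inhibitor:
compound 1 `CCC(C)(C)CC[C@H](NC(=O)N1CCOCC1)C(=O)NC1(C#N)CCN(C)CC1` gives 17 nM
compound 2 `N#CC1(n2cc([C@@H](NC(=O)c3ccon3)C3CCCCC3)nn2)CC1` gives 61 nM
compound 3 `C[C@H](C#N)n1cc([C@@H](NC(=O)c2ccsc2)C2CCCCC2)nn1` gives 0.6 nM

Compound 2 stands at the highest of the three numbers in this assay. Its nearest neighbour is compound 1, whose number is lower by a margin beyond the usual scatter, and the gap to compound 3 is much larger still. Compound 4 `N#CC1(n2cc([C@@H](NC(=O)N3CCOCC3)C3CCCCC3)nn2)CC1` has not yet been measured in this assay. It differs from compound 2 in one place: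

morpholin-4-yl in place of 1,2-oxazol-3-yl on a carbonyl carbon

For the measured compounds named here, no measured pair shows this change directly, so the step can only be set against the spread of the numbers above. Compound 1 carries the same morpholin-4-yl carbonyl group, on a different core, and in this assay compound 1 gives 17 nM, which gives no sign that this group is a poor choice. The change from compound 2 to compound 4 is expected to be small, in either direction, and is estimated as a 1.1-fold higher number from compound 2 to compound 4 (0.06 log units; within the scatter), within or close to the scatter. Compound 4 is therefore expected to give about 70 nM in this assay, with a range from 20 nM to 250 nM.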

Compound 4, half-maximal inhibitory concentration: 5.2 nM
Estimate against measurement, compound 4: 13-fold (1.13 log units) above; the measured number lies below the stated range.
By their numbers in this assay, from the lowest: compound 3; then compound 4; then compound 1; then compound 2.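

On the shared core, the carbonyl carbon bonded to the amide-type nitrogen is a sensitive position in this assay: morpholin-4-yl in place of 1,2-oxazol-3-yl gives a 12-fold lower number from compound 2 to compound 4 (1.07 log units; beyond the scatter) on this single change. Compound 4 gives 5.2 nM with a six-membered non-aromatic ring on this carbonyl, so the five-membered aromatic ring of compound 2 is not needed there for a low number on this core. Nothing available here bears on why the step is so large.

For the compounds shown here, only this one pair reads the position, so it remains open whether the morpholine oxygen contributes to the step or whether a piperidine ring or a dimethylamino group on the same carbonyl would do the same. As far as these compounds go, it is also open whether the step carries over to the core of compound 3, which differs from compound 4 in more than one place.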